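The compounds below may be only part of what the source reports. "The series", "measured", "known", "first", "only" and "open" are said of these compounds alone.

Measured compounds in an assay on isolated protein for agonist activity at Bile acid receptor (Homo sapiens), read by FRET; a lower number here means that less compound is needed, a higher number that more compound is needed for the effect:
compound 1, `CC(C)c1onc(-c2c(Cl)cccc2Cl)c1COc1ccc(N(C)C(=O)c2cccc(C(=O)O)c2)c(C(F)(F)F)n1`, gives 433 nM
compound 2, `CC(C)c1onc(-c2c(Cl)cccc2Cl)c1COc1ccc(N(C)Cc2cccc(C(=O)O)c2)c(C(F)(F)F)n1`, gives 12 nM
compound 3, `CC(C)c1onc(-c2c(Cl)cccc2Cl)c1COc1ccc(N(C)Cc2ccc(OCC(=O)O)cc2)c(C(F)(F)F)n1`, gives 35 nM

Compound 3 sits second of the three in this assay: the step of a 2.9-fold higher number from compound 2 to compound 3 (0.46 log units; beyond the scatter) separates it from compound 2, while the step of a 12-fold lower number from compound 1 to compound 3 (1.09 log units; beyond the scatter) separates it from compound 1. The third measured step, a 36-fold lower number from compound 1 to compound 2 (1.56 log units; beyond the scatter), concerns the same carbonyl-to-methylene exchange on the aromatic nitrogen.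

Compound 4, `CC(C)c1onc(-c2c(Cl)cccc2Cl)c1COc1ccc(N(C)Cc2ccc(OCCO)cc2)c(C(F)(F)F)n1`, differs from compound 3 in one place: hydroxymethyl in place of carboxy on a saturated chain carbon bound to an oxygen on an aromatic ring. For the measured compounds named here, none of the measured steps bears directly on this change, since compounds 1, 2 and 3 all carry a carboxy and only its carrier or position has been varied. The replacement of the acid by an alcohol in this assay is therefore untested in this series, and the direction of the step is a guess rather than an extrapolation; the loss of the acid is expected to raise the number, with a wide range.

Compound 4 is estimated at 150 nM, between 40 nM and 700 nM, an expected step of a 4.3-fold higher number from compound 3 to compound 4 (0.63 log units; beyond the scatter).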

Compound 4, half-maximal effective concentration: 164 nM
Beside the measured number, compound 4's estimate is 1.1-fold (0.04 log units) below it; measured number inside the range.
By their numbers in this assay, from the lowest: compound 2; then compound 3; then compound 4; then compound 1.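

In this assay, for the compounds shown here, the first compound without a carboxy on this chain gives a 4.7-fold higher number from compound 3 to compound 4 (0.67 log units; beyond the scatter), so on this chain carbon, hydroxymethyl in place of carboxy costs a modest step and does not abolish the effect. The carboxy is therefore not required for a measurable number here: the wider comparisons give a 2.6-fold lower number from compound 1 to compound 4 (0.42 log units; beyond the scatter) and a 14-fold higher number from compound 2 to compound 4 (1.14 log units; beyond the scatter), placing the neutral-named 2-hydroxyethoxy compound inside the range set by the carboxy compounds. Nothing available explains the size of this step.

Still open, from the compounds shown here alone, is how a primary carboxamide, an amine or a tetrazole would read at this place on the chain. Equally open, going by these compounds, is whether a longer chain ending in hydroxyl or carboxylic acid would shift the number, and whether a 3-(hydroxymethyl)phenyl in place of 3-carboxyphenyl would cost a similar step.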